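A few compounds are considered here, and "the series" means these few. Any claim that something is new, unique, unknown or untested is made for them only; others in the source may bear on it.

Notes on the series in a functional assay on HCC827 cells (Homo sapiens) for inhibition, read by fluorescence, with a stated time of 72 h; a lower number here means a stronger inhibitor of growth, a higher number a weaker inhibitor of growth.

Compound 1 `CC(C)CCn1cnc2c(Nc3ccccc3)nc(N[C@H]3CC[C@H](N)CC3)nc21` gives 21700 nM in this assay, the highest of the three numbers measured. Compound 2 `CCCCn1cnc2c(Nc3ccccc3)nc(N[C@H]3CC[C@H](N)CC3)nc21` gives 9000 nM, and compound 3 `CCCCCCn1cnc2c(Nc3cc(OC)cc(OC)c3)nc(N[C@H]3CC[C@H](N)CC3)nc21` gives 9100 nM. Going by the values given here, the only single-point step measured so far is a 2.4-fold lower number from compound 1 to compound 2 (0.38 log units; beyond the scatter), a change on the chain rather than on the anilino ring. Among the compounds with values here, compound 3 differs from compound 1 in two places at once, on the chain and on the aryl ring, so its value shows only that a substituted aryl ring combined with a longer chain sits lower than compound 1.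

Compound 4 `CC(C)CCn1cnc2c(Nc3ccc(O)cc3)nc(N[C@H]3CC[C@H](N)CC3)nc21` is compound 1 with hydroxy in place of hydrogen on an aromatic carbon. Within the data shown here, no measured step touches the aryl ring alone, so the chain step gives no direct guide; the change in compound 4 is smaller than either measured pair suggests. A step of a 1.4-fold lower number from compound 1 to compound 4 (0.13 log units; within the scatter) is expected, that is a number close to compound 1 within the scatter. Compound 4 is therefore estimated at 16000 nM, with a range from 5000 nM to 50000 nM.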

Compound 4, concentration for 50% growth inhibition: 14400 nM
For compound 4 the middle estimate is 1.1-fold (0.05 log units) above the measured one, within the range that was stated.
By their numbers in this assay, from the lowest: compounds 2, 3, 4 and 1 (each within the scatter of the next, the first and the last beyond it).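

Going by these compounds alone, this is the first single change on the aryl ring that can be read in this assay on its own: phenyl to 4-hydroxyphenyl on an otherwise unaltered compound 1 gives a 1.5-fold lower number from compound 1 to compound 4 (0.18 log units; within the scatter) and so hydroxy and hydrogen on this aromatic carbon, para to a large group, cannot be told apart. Within the data shown here, the chain step, a 2.4-fold lower number from compound 1 to compound 2 (0.38 log units; beyond the scatter) remains the only single change printed as beyond the scatter. No measurement on hand bears on the reason for this result.

As far as these compounds go, whether an amine or a carboxylic acid on this same carbon would also stay within the scatter of compound 1 remains open. Also open, from the compounds shown here alone, is whether the hydroxy step reads the same on the chain of compound 2.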